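Swapping Methylsulfonyl for Vinyl on a Weakly Cytotoxic Core

A few compounds are considered here, and "the series" means these few. Any claim that something is new, unique, unknown or untested is made for them only; others in the source may bear on it.

Compound 1, `C/C(=C\c1cc(-c2ccc(C#N)cc2)cs1)C(N)=O`: > 50000 nM
Compound 2, `C/C(=C\c1cc(-c2ccc(S(C)(=O)=O)cc2)cs1)C(N)=O`: > 50000 nM

Both numbers come from a functional assay on A549 cells (Homo sapiens) for cytotoxicity, read by CCK-8 assay, with a stated time of 24 h; a lower number here means a stronger inhibitor, a higher number a weaker inhibitor. For compound 1 the value > 50000 nM is a limit of the assay and not a measured number. For compound 2 the value > 50000 nM is likewise a limit. Because both values sit at the limit of > 50000 nM in this assay, at which 2 of the 2 values shown sit, the step that the two limits leave unreadable from compound 1 to compound 2 cannot be read, and compound 2 therefore stands at the limit, with no measured number to place it above or below compound 1.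

Compound 3, `C=Cc1ccc(-c2csc(/C=C(\C)C(N)=O)c2)cc1`, differs from compound 2 in one place: vinyl in place of methylsulfonyl on an aromatic carbon. Going by the values given here, the only measured step, the one from compound 1 to compound 2, concerns a different exchange and is itself unreadable, so no measured step gives the size or direction of this change. Compound 3 is expected to give 80000 nM, within a range from 20000 nM to 300000 nM, and most likely again only a limit. The step that the limit leaves unreadable from compound 2 to compound 3 is accordingly expected to be no larger than the scatter, with no direction that can be read.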

Compound 3, half-maximal inhibitory concentration: > 50000 nM
Compound 3: no number, only a limit; the forecaster's own chance of this, stated with the estimate: 80%; the middle value is on the limit's open side.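

In this assay compound 3 gives > 50000 nM, which is a limit of the assay and not a number. No step among compound 1, compound 2 and compound 3 can be read, because the values share one limit: the limit of > 50000 nM in this assay, at which 3 of the 3 values shown sit.

The compounds shown leave open whether cyano, methylsulfonyl or vinyl makes any difference to cytotoxicity in these cells.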